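Replacing 3,4-dichlorophenyl with 3-acetylphenyl

A few compounds are considered here, and "the series" means these few. Any claim that something is new, unique, unknown or untested is made for them only; others in the source may bear on it.

Measured in a functional assay on HepG2 cells (Homo sapiens) for antiproliferative activity, with a stated time of 72 h; a lower number here means that less compound is needed, a higher number that more compound is needed for the effect:
- compound 1 `COC(=O)c1cc(=O)c2cc(NC(=O)Nc3ccc(Cl)c(C(F)(F)F)c3)ccc2[nH]1`: > 6350 nM
- compound 2 `COC(=O)c1cc(=O)c2cc(NC(=O)Nc3ccc(Cl)c(Cl)c3)ccc2[nH]1`: > 6350 nM

Compound 2 gives no number here, only the limit > 6350 nM. Compound 1 also gives only a limit, > 6350 nM. The measured series therefore stands at the limit of > 6350 nM in this assay, at which 2 of the 2 values shown sit, and compound 2 cannot be placed more exactly.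

The next compound is compound 3 `COC(=O)c1cc(=O)c2cc(NC(=O)Nc3cccc(C(C)=O)c3)ccc2[nH]1`, which carries 3-acetylphenyl in place of 3,4-dichlorophenyl on an amide-type nitrogen.

Going by the values given here, only one measured step is available for comparison, a step that the two limits leave unreadable from compound 1 to compound 2. It puts chloro in place of trifluoromethyl on an aromatic carbon, a different change from the one made here, and it offers no size to carry over. Among the compounds with values here, no measured compound carries 3-acetylphenyl. With no readable step to point either way, no clear shift is expected in this assay, and compound 3 is expected most likely to report a limit as well. The expected change is a step that the limit leaves unreadable from compound 2 to compound 3. For compound 3 the estimate is 9000 nM, with an expected range from 3500 nM to 25000 nM.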

Compound 3, half-maximal effective concentration: > 8080 nM
Compound 3 ended at the assay's limit; the forecaster's own chance of this, stated with the estimate: 75%; the middle value does not contradict the limit.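

In this assay compound 3 gives only a limit, > 8080 nM. Going by these compounds alone, compound 2 also gives only a limit, > 6350 nM, so no step between compound 2 and compound 3 can be read. The compounds shown leave open whether 3-acetylphenyl in place of 3,4-dichlorophenyl on the amide-type nitrogen changes the antiproliferative effect at all.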